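Hydrazone variation on a shared core: notes toward compound 4

The source may report more compounds than this note shows. Statements on the series, on what has been measured and on what is new or still open speak of the compounds shown alone.

compound 1 `CCCSc1nc(N/N=C/c2ccc(C)cc2)c2nnn(Cc3ccccc3)c2n1`: in a functional assay on ECa-109 cells (Homo sapiens) for antiproliferative activity, read by MTT assay, with a stated time of 72 h (on this read-out higher numbers stand for weaker inhibition and lower numbers for stronger inhibition), compound 1 gives > 64000 nM, a limit of the assay and not a number.
compound 2 `CCCSc1nc(N/N=C/c2ccc3ccccc3c2)c2nnn(Cc3ccccc3)c2n1`: in this assay compound 2 gives > 64000 nM, again a limit of the assay.
compound 3 `CCCSc1nc(N/N=C/c2c[nH]c3ccccc23)c2nnn(Cc3ccccc3)c2n1`: in this assay compound 3 gives 8690 nM.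

Compound 1 therefore stands at the limit (the limit of > 64000 nM in this assay, at which 2 of the 3 values shown sit), where two of the three measured values sit; only compound 3 returns a number. Within the data shown here, the step of an at least 7.3-fold lower number from compound 1 to compound 3 (0.86 log units; beyond the scatter) is the one readable step from compound 1, and the step of an at least 7.3-fold lower number from compound 2 to compound 3 (0.86 log units; beyond the scatter) mirrors it. The step that the two limits leave unreadable from compound 1 to compound 2 remains unreadable, as both ends are limits.

Compound 4 `CCCSc1nc(N/N=C(\C)c2ccc(Br)cc2)c2nnn(Cc3ccccc3)c2n1` differs from compound 1 by a group of 10 heavy atoms (8 carbon, 1 nitrogen, 1 bromine; one six-membered aromatic ring of carbon only) in place of a group of 9 heavy atoms (8 carbon, 1 nitrogen; one six-membered aromatic ring of carbon only), on a nitrogen on an aromatic ring. Neither measured step involves a change of this kind, since both readable steps bring in 1H-indol-3-yl. With the 4-methylphenyl-like six-membered carbon ring retained in compound 4, no step beyond the scatter is expected, and the value of compound 4 in this assay is expected to stay near the limit of compound 1, so that an at least 1.2-fold lower number from compound 1 to compound 4 (0.10 log units; that floor lies within the scatter) is estimated to be small. The estimate for compound 4 is 50000 nM, within 9000 nM to 200000 nM.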

Compound 4, half-maximal inhibitory concentration: 4670 nM
Beside the measured number, compound 4's estimate is 11-fold (1.03 log units) above it; the whole stated range lies above it.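

In this assay, the exchange of groups on a nitrogen on an aromatic ring gives an at least 13-fold lower number from compound 1 to compound 4 (1.13 log units; beyond the scatter), with the six-membered aromatic ring of carbon only kept in both groups. The earlier readable steps all brought in 1H-indol-3-yl, whereas compound 4 returns a number without that group. The size of this step is only a floor, as compound 1 is a limit of the assay and not a number: the limit of > 64000 nM in this assay, at which 2 of the 4 values shown sit.

The step exchanges the whole group, so the part played by the bromine cannot be separated from the other differences between the two groups. As far as these compounds go, it remains open whether a chlorine, a methoxy group or a dimethylamino group in place of the bromine would keep a measurable number, and whether a longer chain on the sulfur would change it.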